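Swapping an arylmethyl for an aryl ether on the core

A few compounds are considered here, and "the series" means these few. Any claim that something is new, unique, unknown or untested is made for them only; others in the source may bear on it.

Compound 2 `COc1ccc(F)cc1CNCCCNc1ccnc2cc(Cc3cc(C)cc(C)c3)ccc12` gives the lowest of the three numbers recorded in an ADME assay on HepG2 cells (Homo sapiens) for cytotoxicity, read by luminescence, CellTiter-Glo and ATP content, with a stated time of 72 h (on this read-out higher numbers stand for an effect only at larger amounts of compound and lower numbers for an effect already at smaller amounts), at 940 nM. Compound 1 `COc1ccccc1Oc1ccc2c(NCCCNCc3ccco3)ccnc2c1` gives 6500 nM and compound 3 `c1ccc(Oc2ccc3c(NCCCNCc4ccco4)ccnc3c2)cc1` gives 15200 nM in this assay; both carry an aryl ether where compound 2 carries an arylmethyl group. Compound 4 `COc1cccc(Oc2ccc3c(NCCCNCc4cc(F)ccc4OC)ccnc3c2)c1` differs from compound 2 in one place: 3-methoxyphenoxy in place of 3,5-dimethylbenzyl on an aromatic carbon. For the measured compounds named here, no measured step covers this exact exchange. Going by the values given here, the one measured step, a 2.3-fold higher number from compound 1 to compound 3 (0.37 log units; beyond the scatter), concerns only a methoxy within an aryl ether. Since compounds 1 and 3 with aryl ethers both show higher numbers than compound 2, the expected step is a 4.8-fold higher number from compound 2 to compound 4 (0.68 log units; beyond the scatter), upward, beyond the scatter. Compound 4 is estimated at 4500 nM, within 1500 nM to 14000 nM.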

Compound 4, half-maximal effective concentration: 7100 nM
For compound 4 the middle estimate is 1.6-fold (0.20 log units) below the measured one, and the stated range covers the measured number.
By their numbers in this assay, from the lowest: compound 2; then compounds 1 and 4 (each within the scatter of the next); then compound 3.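

In this assay, the exchange at this aromatic carbon of the shared core now has a direct reading: 3-methoxyphenoxy in place of 3,5-dimethylbenzyl gives a 7.6-fold higher number from compound 2 to compound 4 (0.88 log units; beyond the scatter). Both groups have 9 heavy atoms and one six-membered aromatic ring of carbon only, whereas the entering group has 2 hydrogen-bond acceptors and the leaving group 0. Nothing available explains this step. The compounds shown leave open how a phenylamino or benzoyl group would read at this carbon, and whether the step would keep its size with a different amine side chain.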